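Trimethoxy chalcone series: adding a third methoxy

A few compounds are considered here, and "the series" means these few. Any claim that something is new, unique, unknown or untested is made for them only; others in the source may bear on it.

Compound 1 `COc1ccc(C(=O)/C=C/c2cc(-c3cc(OC)c(OC)c(OC)c3)n[nH]2)cc1OC`: 39%
Compound 2 `COc1ccc(C(=O)/C=C/c2cc(-c3cc(OC)c(OC)c(OC)c3)n[nH]2)cc1`: 62%

In a functional assay on CCRF-CEM cells (Homo sapiens) for cytotoxicity, read by sulforhodamine B assay, with a stated time of 48 h, tested at 1 uM (a lower number here means a stronger effect, a higher number a weaker effect of the compound at the concentration tested), compound 1 gives the lowest of the two numbers shown, with compound 2 nearest to it, and the single measured step of a number 23 percentage points higher from compound 1 to compound 2 (beyond the scatter) shows that hydrogen in place of methoxy weakened the effect. Compound 3 `COc1cc(C(=O)/C=C/c2cc(-c3cc(OC)c(OC)c(OC)c3)n[nH]2)cc(OC)c1OC` differs from compound 1 by methoxy in place of hydrogen on an aromatic carbon, the reverse kind of change on the same ring. Since removing a methoxy raised the number in this assay, adding one is expected to lower it somewhat or leave it unchanged; the estimated step is a number 9 percentage points lower from compound 1 to compound 3 (within the scatter). Compound 3 is therefore expected at 30%, between 12% and 52%.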

Compound 3, a percentage reported as activity, at one concentration (the size of the read-out at that concentration, not a potency): 67%
The estimate for compound 3 lay 37 percentage points below the measured number; the whole stated range lies below it.
By their numbers in this assay, from the lowest: compound 1; then compounds 2 and 3 (each within the scatter of the next).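

In this assay, adding a methoxy at this position, ortho to a methoxy group, gives a number 28 percentage points higher from compound 1 to compound 3 (beyond the scatter), so the change weakens the effect, as the removal of a methoxy did in a number 23 percentage points higher from compound 1 to compound 2 (beyond the scatter). Among these three compounds, the effect therefore does not grow with the number of methoxy groups on this ring, and compound 1 gives the lowest number. Nothing available explains this rise.

From the compounds shown here alone, it remains open whether a hydroxyl, a fluorine or an amine at this position would match compound 1 or weaken the effect likewise.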